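Fluoro for chloro on the aryl ether of compound 2

The compounds below may be only part of what the source reports. "The series", "measured", "known", "first", "only" and "open" are said of these compounds alone.

Measured compounds in an in vitro assay on HEK293 cells for inhibition of sodium-dependent dopamine transporter (Homo sapiens); on this read-out higher numbers stand for weaker inhibition and lower numbers for stronger inhibition:
compound 1, `CNC[C@]1(O)Cc2ccccc2[C@@H]1Oc1ccc(O)cc1C`, 5000 nM
compound 2, `CNC[C@]1(O)Cc2ccccc2[C@@H]1Oc1ccccc1Cl`, 10000 nM
compound 3, `CNCC1(O)Cc2ccccc2C1Cc1ccccc1C`, > 10000 nM

Compound 2 gives the higher of the two numbers in this assay, and compound 1 gives a lower one, but the gap between them lies within the scatter, so no order between compound 1 and compound 2 can be read from these two values. The value of compound 3 is a limit of this assay, not a number (the limit of > 10000 nM in this assay, at which 1 of the 3 values shown sits).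

Compound 4, `CNC[C@]1(O)Cc2ccccc2[C@@H]1Oc1ccccc1F`, differs from compound 2 by a single change: fluoro in place of chloro on an aromatic carbon. For the measured compounds named here, no measured pair in this set shows the same exchange, so there is no step to lean on. Since compound 2 gives 10000 nM in this assay, compound 4 is expected to land close to it, with no step beyond the scatter in either direction. Compound 4 is expected to give 12000 nM in this assay, in a range from 5000 nM to 30000 nM. This expectation corresponds to a step of a 1.2-fold higher number from compound 2 to compound 4 (0.08 log units; within the scatter).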

Compound 4, half-maximal inhibitory concentration: 4000 nM
Compound 4: the middle estimate sits 3.0-fold (0.48 log units) above what was measured, outside the stated range (below it).
By their numbers in this assay, from the lowest: compounds 4, 1 and 2 (each within the scatter of the next, the first and the last beyond it).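

In this assay, for the compounds shown here, the change from 2-chlorophenyl to 2-fluorophenyl gives the first step in this set that can be read, a 2.5-fold lower number from compound 2 to compound 4 (0.40 log units; beyond the scatter). Going by these compounds alone, it shows that this aromatic carbon, ortho to a large group, is not indifferent to the halogen it carries, though the effect is modest; the earlier compounds could not show this, as no two of them differed in one place only. Compound 3 still offers no number to compare, since its value is a limit: the limit of > 10000 nM in this assay, at which 1 of the 4 values shown sits.

What the compounds shown leave open is how a methoxy group, a nitrile or a plain hydrogen would fare on this same carbon. Also open, as far as these compounds go, is whether the fluoro for chloro step would hold with a longer chain in place of the methyl on the amine.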